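A few compounds are considered here, and "the series" means these few. Any claim that something is new, unique, unknown or untested is made for them only; others in the source may bear on it.

Compound 3 `O=C(O)c1csc(SCCN2C(=O)CC[C@@H]2/C=C/[C@@H](O)Cc2cccc(-c3ccccc3)c2)n1` stands lowest of the numbers shown: in an assay on CHO cells for displacement of a labelled ligand from prostaglandin E2 receptor EP2 subtype (Mus musculus), read by scintillation counting, with a stated time of 60 min (a lower number here means a stronger inhibitor, a higher number a weaker inhibitor), compound 3 gives 3 nM. Compound 1 `O=C(O)CCCSCCN1C(=O)CC[C@@H]1/C=C/[C@@H](O)Cc1cccc(-c2nc3ccccc3s2)c1`, which carries a different group on the same aromatic carbon, gives 720 nM in this assay, a higher number beyond the scatter. For compound 2 `O=C(O)CCCSCCN1C(=O)CC[C@@H]1/C=C/[C@@H](O)Cc1cccc(OCc2ccncc2)c1` this assay returns only a limit, > 10000 nM. Within the data shown here, the one measured step, an at least 13-fold higher number from compound 1 to compound 2 (1.14 log units; beyond the scatter), exchanges the whole group on that carbon and its size is bounded by the limit of > 10000 nM in this assay, at which 1 of the 3 values shown sits.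

Compound 4 `O=C(O)c1csc(SCCN2C(=O)CC[C@@H]2/C=C/[C@@H](O)Cc2cccc(-c3ccc(Cl)cc3)c2)n1` differs from compound 3 by chloro in place of hydrogen on an aromatic carbon, on an aromatic carbon of a six-membered aromatic ring of carbon only, para to a large group. Among the measured compounds shown here, no measured step changes a substituent on this phenyl; the step from compound 1 to compound 2 exchanges the group itself, so it bears on compound 4 only loosely. The expected step, no change at the digits printed from compound 3 to compound 4 (within the scatter), is therefore one within the scatter, in no set direction. Compound 4 is estimated at 3 nM in this assay, within 1 nM to 10 nM.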

Compound 4, inhibition constant: 1.7 nM
Compound 4: middle estimate off by 1.8-fold (0.25 log units), on the high side, within the range that was stated.
By their numbers in this assay, from the lowest: compounds 4 and 3 (each within the scatter of the next); then compound 1. At a limit, above all of these: compound 2.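

In this assay, among these compounds, the change from phenyl to 4-chlorophenyl gives a 1.8-fold lower number from compound 3 to compound 4 (0.25 log units; within the scatter), and this is the first measured change of a substituent on this ring rather than an exchange of the whole group. It shows that one chlorine, on an aromatic carbon para to a large group, leaves the number unchanged within the scatter, so this position accepts the added atom without a measurable loss or gain. No measured property shown here bears on this result.

As far as these compounds go, it remains open whether a methoxy group, an amine or a carboxylic acid at the same place would also stay within the scatter. From the compounds shown here alone, it is equally open whether the same chloro change would give a similar result on the core of compound 1.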